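The source may hold more compounds than are shown below. What is called first, only, known or untested is meant among the compounds shown, and "the series" means these compounds.

Working notes on the series.

Compound 1 `CO[C@H]1O[C@H](COc2ccc3c(c2)CCCC3)[C@@H](O)[C@H](O)[C@H]1Oc1cccc(C(C)C)c1` and compound 2 `CO[C@H]1O[C@H](COc2ccc(-c3ccccc3)cc2)[C@@H](O)[C@H](O)[C@H]1Oc1ccccc1` share the same sugar core and differ in the two aryl groups attached to it. In a functional assay on HeLa cells (Homo sapiens) for cytotoxicity, read by MTT assay, with a stated time of 48 h (on this read-out lower numbers stand for an effect already at smaller amounts and higher numbers for an effect only at larger amounts of compound), compound 1 gives 33000 nM, and compound 2 gives 33000 nM; the two values are level at the digits shown, within the usual scatter. For compound 3 `CO[C@@H]1O[C@H](COc2ccc(-c3ccccc3)cc2)[C@@H](O)[C@H](O)[C@H]1Oc1ccccc1` the entry in this assay reads "not determined" (no result reported), with no result recorded; (the fact that compounds 2 and 3 differ only in the configuration as drawn), so nothing can be said of that pair.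

Compound 4 `CO[C@H]1O[C@H](COc2ccc(-c3ccccc3)cc2)[C@@H](O)[C@H](O)[C@H]1Oc1ccc(C(C)C)cc1` is the next step from compound 2. The change is isopropyl in place of hydrogen on an aromatic carbon. For the measured compounds named here, no measured pair isolates this change. Compound 1, which also carries an isopropyl on one of its aryl groups, though in a different arrangement, sits level with compound 2 in this assay, so the step from compound 2 to compound 4 is expected to stay within the scatter, with no change at the digits printed from compound 2 to compound 4 (within the scatter) as the estimated size, in neither direction beyond it. Compound 4 is therefore expected to give about 33000 nM in this assay, with a range from 12000 nM to 90000 nM.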

Compound 4, half-maximal effective concentration: 19000 nM
Estimate against measurement, compound 4: 1.7-fold (0.24 log units) above; measured number inside the range.
By their numbers in this assay, from the lowest: compounds 4, 1 and 2 (each within the scatter of the next).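

In this assay, isopropyl in place of hydrogen on an aromatic carbon, para to a large group, gives a 1.7-fold lower number from compound 2 to compound 4 (0.24 log units; within the scatter), so the change from phenoxy to 4-isopropylphenoxy on this scaffold does not move the result beyond the scatter. For the compounds shown here, this is the first measured pair that isolates this change, as compounds 1 and 2 differ in both aryl groups. Nothing available here bears on a reason for this result.

Going by these compounds, whether the same place tolerates groups of another kind, such as an amine, a carboxylic acid or a longer chain, remains open, as does the effect of isopropyl on the other aryl group. On these data alone, the pair of compound 2 and compound 3 cannot be read, so the effect of the configuration as drawn also remains open.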